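The source may hold more compounds than are shown below. What is called first, only, known or untested is meant among the compounds shown, and "the series" means these compounds.

Of the compounds shown here, two that share one core have been measured in an ADME assay on HEL cells (Homo sapiens) for cytotoxicity, with a stated time of 3 days; a higher number here means that more compound is tolerated, a lower number that less compound is tolerated. Compound 1, `Cc1cc(-c2ccsc2)c2ncc(CSCCc3ccccc3)n2c1`, returns a limit of the assay rather than a number in this assay, > 50 ug/mL. Compound 2, `Cc1cc(-c2cccc([N+](=O)[O-])c2)c2ncc(CSCCc3ccccc3)n2c1`, gives 47 ug/mL in this assay. For the measured compounds named here, the one step between them, an at least 1.0-fold lower number from compound 1 to compound 2 (0.02 log units; that floor lies within the scatter), exchanges thiophen-3-yl for 3-nitrophenyl on an aromatic carbon, and its true size cannot be read beyond the floor set by the limit of > 50 ug/mL in this assay, at which 1 of the 2 values shown sits. Compound 2 thus stands at the only number shown; the other value is a limit. Compound 3, `COc1cccc(-c2cc(C)cn3c(CSCCc4ccccc4)cnc23)c1`, differs from compound 2 by methoxy in place of nitro on an aromatic carbon. Going by the values given here, the single measured step bears on it only loosely: it too changed the group carried on that six-membered aromatic ring of carbon only, and it stayed within the usual scatter. The expected step is therefore small, a 1.0-fold higher number from compound 2 to compound 3 (0.01 log units; within the scatter), with no clear direction. Compound 3 is estimated to give about 48 ug/mL in this assay, between 24 ug/mL and 60 ug/mL, and it may well come back as a limit of the assay.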

Compound 3, half-maximal cytotoxic concentration: > 50 ug/mL
Compound 3: no number, only a limit; the forecaster's own chance of this, stated with the estimate: 50%; at least 1.0-fold (0.01 log units) between middle value and limit.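

Exchanging nitro for methoxy on this six-membered aromatic ring of carbon only gives an at least 1.0-fold higher number from compound 2 to compound 3 (0.02 log units; that floor lies within the scatter) in this assay. For the compounds shown here, this is the first look at a change to a group on the ring rather than a change of the ring itself, and like the earlier step, it gives only a floor that stays within the scatter, so the true size of the step remains unknown. Compound 3 is now a limit as well, compound 2 remains the only compound with an actual number, and the step between compound 1 and compound 3 cannot be read, so the limit governs most of what this small set can say: the limit of > 50 ug/mL in this assay, at which 2 of the 3 values shown sit.

From the compounds shown here alone, it remains open how far the true values of compound 1 and compound 3 lie from that limit, and therefore whether the nitro group of compound 2 makes any real difference in this assay. Also open, going by these compounds, is whether an amine or a carboxylic acid in the same place on the ring, or a longer chain in place of methoxy, would give a number that can be read.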